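The source may hold more compounds than are shown below. What is called first, only, known or untested is meant among the compounds shown, and "the series" means these compounds.

Compound 1 (`CCCCc1cc2c(=O)c(C(C)=O)c[nH]c2cc1OCCOc1ccccc1`), compound 2 (`CCCCc1cc2c(=O)c(C(=O)O)c[nH]c2cc1OCCOc1ccccc1`) and compound 3 (`CCCCc1cc2c(=O)c(C(=O)NC)c[nH]c2cc1OCCOc1ccccc1`) share one core and were examined in an ADME assay on J774 cells (Mus musculus) for cytotoxicity; on this read-out higher numbers stand for an effect only at larger amounts of compound and lower numbers for an effect already at smaller amounts. In this assay compound 1 has the entry "not determined" (no result reported). Compound 2 gives > 20000 nM, which is a limit. Compound 3 gives > 20000 nM, which is likewise a limit, so it stands at the limit of > 20000 nM in this assay, at which 2 of the 3 values shown sit. Compound 4 (`CCCCc1cc2c(=O)c(C(=O)NCCO)c[nH]c2cc1OCCOc1ccccc1`) differs from compound 3 by hydroxymethyl in place of hydrogen on a saturated chain carbon bound to an amide-type nitrogen, turning methylcarbamoyl into (2-hydroxyethyl)carbamoyl. Going by the values given here, the only measured step that bears on this change is a step that the two limits leave unreadable from compound 2 to compound 3, and it offers no size to build on. No shift beyond the scatter is therefore expected, and the estimate is a step that the limit leaves unreadable from compound 3 to compound 4. For compound 4 the expected value is 28000 nM, with an estimated range from 14000 nM to 56000 nM.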

Compound 4, half-maximal effective concentration: > 20000 nM
Compound 4 gave a limit, no number; the forecaster's own chance of this, stated with the estimate: 85%; the middle value is on the limit's open side.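

The steps among compound 2, compound 3 and compound 4 cannot be read in this assay, because all three sit at one limit: the limit of > 20000 nM in this assay, at which 3 of the 4 values shown sit.

The compounds shown leave open how far beyond that limit any of them lies, and where compound 1 stands.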